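The source may report more compounds than this note shows. Statements on the series, on what has been measured and on what is new or still open speak of the compounds shown alone.

Compound 1 `CCN(CC)Cc1cc(Nc2nc3ccccc3n2Cc2ccc(C(F)(F)F)cc2)ccc1O` in an ADME assay on CHO cells (Cricetulus griseus) for inhibition, read by MTT assay (a lower number here means a stronger inhibitor, a higher number a weaker inhibitor), gives 17500 nM. Compound 2 `CCN(CC)Cc1cc(Nc2nc3ccccc3[nH]2)ccc1O` reaches only a limit in this assay, > 50000 nM. On these data alone, the change hydrogen in place of 4-(trifluoromethyl)benzyl on an aromatic nitrogen thus produces an at least 2.8-fold higher number from compound 1 to compound 2 (0.45 log units; beyond the scatter); the true size of that step stays open because the limit of > 50000 nM in this assay, at which 1 of the 3 values shown sits, cuts the value off. Compound 3 `CCN(CC)Cc1ccc(C)c(Nc2nc3ccccc3n2Cc2ccc(C(F)(F)F)cc2)c1O` carries a different core, and the difference between the two cores is not broken down here. In this assay compound 3 gives 33900 nM, a value within the scatter of that of compound 1. Compound 4 `CCN(CC)Cc1ccc(C)c(Nc2nc3ccccc3[nH]2)c1O` is the unmeasured partner of compound 3 and differs from it by hydrogen in place of 4-(trifluoromethyl)benzyl on an aromatic nitrogen, the same change as that from compound 1 to compound 2, at a place described in identical words. Resting on an at least 2.8-fold higher number from compound 1 to compound 2 (0.45 log units; beyond the scatter), the expected step is a 2.4-fold higher number from compound 3 to compound 4 (0.37 log units; beyond the scatter), with a high chance of a limit. Compound 4 is estimated at 80000 nM.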

Compound 4, half-maximal inhibitory concentration: > 50000 nM
Compound 4 was reported as a limit; the forecaster's own chance of this, stated with the estimate: 70%; the middle value does not contradict the limit.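

In this assay, compound 4 gives only a limit, > 50000 nM, not a number. Hydrogen in place of 4-(trifluoromethyl)benzyl on the aromatic nitrogen gives an at least 1.4-fold higher number from compound 3 to compound 4 (0.16 log units; that floor lies within the scatter), so the result does not go against the step seen on the core of compound 1, yet its floor alone does not show that the change carries over to the core of compound 3. Nor can the two steps be compared in size: the same change on two cores in this assay, an at least 2.8-fold higher number (0.45 log units; beyond the scatter) from compound 1 to compound 2 and an at least 1.4-fold higher number (0.16 log units; that floor lies within the scatter) from compound 3 to compound 4; the limit leaves it open whether they differ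

On these data alone, the values behind the limits of compound 2 and compound 4 stay open: the limit of > 50000 nM in this assay, at which 2 of the 4 values shown sit. Also open is what a methyl group or a longer alkyl chain on that aromatic nitrogen would give on either core in this assay.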